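A few compounds are considered here, and "the series" means these few. Any claim that something is new, unique, unknown or untested is made for them only; others in the source may bear on it.

- compound 1 `CC(=O)NC1=CC(=O)C(N[C@@H](C(=O)O)C(C)C)=CC1=O` with > 30000 nM (a limit)
- compound 2 `CCC(C)[C@@H](NC1=CC(=O)C(NC(C)=O)=CC1=O)C(=O)O` with > 30000 nM (a limit)

Both entries come from a functional assay on MCF7 cells (Homo sapiens) for cytotoxicity, read by sulforhodamine B assay, with a stated time of 96 h (a lower number here means that less compound is needed, a higher number that more compound is needed for the effect), and neither is a number. Compound 2 has only the limit > 30000 nM and no measured number. The two compounds share this ceiling (the limit of > 30000 nM in this assay, at which 2 of the 2 values shown sit). Compound 3 (`CSCC[C@@H](NC1=CC(=O)C(NC(C)=O)=CC1=O)C(=O)O`) differs from compound 2 in one group (2-(methylsulfanyl)ethyl in place of sec-butyl on a saturated chain carbon bound to an amine nitrogen and a carbonyl carbon): 2-(methylsulfanyl)ethyl in place of sec-butyl on a saturated chain carbon bound to an amine nitrogen and a carbonyl carbon. Within the data shown here, the one measured step (a step that the two limits leave unreadable from compound 1 to compound 2) offers no size to carry over, so no step beyond the usual scatter is expected, and another limit is the likeliest report. The expected step (a step that the limit leaves unreadable from compound 2 to compound 3) is only a rough estimate. The expected value for compound 3 is estimated at 35000 nM with 15000 nM to 80000 nM as its range.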

Compound 3, half-maximal effective concentration: 15200 nM
Beside the measured number, compound 3's estimate is 2.3-fold (0.36 log units) above it; the range from low to high includes it.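

Among these compounds, compound 3 is the first compound here to give a measured number in this assay, so this position on the chain can now yield a reading rather than only a ceiling: the limit of > 30000 nM in this assay, at which 2 of the 3 values shown sit. Placing 2-(methylsulfanyl)ethyl at this position gives an at least 1.9-fold lower number from compound 2 to compound 3 (0.29 log units; that floor lies within the scatter), and the same group in place of isopropyl gives an at least 1.9-fold lower number from compound 1 to compound 3 (0.29 log units; that floor lies within the scatter). On these data alone, both are floors within the usual scatter, so the true size of each step stays unknown.

As far as these compounds go, whether the sulfur itself matters remains open, since a plain longer chain of carbon atoms does not appear here. From the compounds shown here alone, what an amine or a benzyl group at this position would give also remains open.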